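The source may hold more compounds than are shown below. What is called first, only, known or untested is meant among the compounds shown, and "the series" means these compounds.

Compounds measured in a functional assay on KB cells (Homo sapiens) for cytotoxicity; a higher number here means a weaker inhibitor, a lower number a stronger inhibitor:
compound 1 `COc1ccc(S(=O)(=O)N2CCc3cccc(NC(=O)c4cccs4)c32)cc1` gives 47 nM;
compound 2 `COc1ccc(S(=O)(=O)N2CCc3cccc(NC(=O)c4ccc([N+](=O)[O-])cc4)c32)cc1` gives 102 nM;
compound 3 `COc1ccc(S(=O)(=O)N2CCc3cccc(NC(=O)c4ccccc4)c32)cc1` gives 297 nM.

Among these three, compound 2 holds the middle place, with compound 1 the nearer neighbour and compound 3 the further one: a 2.2-fold higher number from compound 1 to compound 2 (0.34 log units; beyond the scatter) and a 2.9-fold higher number from compound 2 to compound 3 (0.46 log units; beyond the scatter). Compound 4 `COc1ccc(C(=O)Nc2cccc3c2N(S(=O)(=O)c2ccc(OC)cc2)CC3)cc1` is not yet measured in this assay. It differs from compound 2 by methoxy in place of nitro on an aromatic carbon.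

Going by the values given here, the step that bears most directly on this change is the one from compound 2 to compound 3, in which nitro gives way to hydrogen at the same aromatic carbon: a 2.9-fold higher number from compound 2 to compound 3 (0.46 log units; beyond the scatter). Methoxy is a different entry from hydrogen, and no measured pair shows its effect at that place, so the direction is uncertain; a modest rise in the number, a 2.0-fold higher number from compound 2 to compound 4 (0.29 log units; within the scatter), is expected. Compound 4 is estimated at 200 nM, with a range from 70 nM to 600 nM.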

Compound 4, half-maximal inhibitory concentration: 2600 nM
Beside the measured number, compound 4's estimate is 13-fold (1.11 log units) below it; the measured number lies above the stated range.
By their numbers in this assay, from the lowest: compound 1; then compound 2; then compound 3; then compound 4.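

In this assay, the aromatic carbon para to a large group proves far more sensitive than the nitro-to-hydrogen change suggested, with a 25-fold higher number from compound 2 to compound 4 (1.41 log units; beyond the scatter) and an 8.8-fold higher number from compound 3 to compound 4 (0.94 log units; beyond the scatter), so hydrogen does not mark the upper end of the numbers at this place. Against the thiophen-2-yl amide, 4-methoxyphenyl gives the widest step of the series, a 55-fold higher number from compound 1 to compound 4 (1.74 log units; beyond the scatter). No available evidence accounts for this rise.

The compounds shown leave open where an amine or a chlorine atom on the same carbon would fall relative to hydrogen and methoxy.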